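Fluoro on the pendant phenyl of the aza core

The source may hold more compounds than are shown below. What is called first, only, known or untested is meant among the compounds shown, and "the series" means these compounds.

Of the compounds shown here, three have been measured in a functional assay on the whole organism (trachea) for inhibition, with Cavia porcellus as the target; on this read-out higher numbers stand for an effect only at larger amounts of compound and lower numbers for an effect already at smaller amounts. Compound 1 `CN(Cc1cc(C(F)(F)F)cc(C(F)(F)F)c1)C(=O)c1c(-c2ccccc2)c2ccccc2c(=O)n1C` gives 45.7 mg/kg. Where compound 1 has carbon in its core, compound 2 `CN(Cc1cc(C(F)(F)F)cc(C(F)(F)F)c1)C(=O)c1c(-c2ccccc2)c2cccnc2c(=O)n1C` carries a ring nitrogen, and compound 2 gives 0.027 mg/kg. Compound 3 `Cc1cc2c(-c3ccccc3)c(C(=O)N(C)Cc3cc(C(F)(F)F)cc(C(F)(F)F)c3)n(C)c(=O)c2cc1C`, with two methyl groups on the fused ring, gives 0.49 mg/kg. Within the data shown here, compound 2 thus has the lowest number of the three; the nearest is compound 3 and the furthest compound 1, and both gaps lie beyond the scatter, so compound 2 is the most potent compound in this assay so far.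

Compound 4 `CN(Cc1cc(C(F)(F)F)cc(C(F)(F)F)c1)C(=O)c1c(-c2ccc(F)cc2)c2cccnc2c(=O)n1C` is not yet measured in this assay. It differs from compound 2 in one place: fluoro in place of hydrogen on an aromatic carbon. Among the measured compounds shown here, no pair of measured compounds differs by a single change of this kind, so no step is available as a guide; the difference is a single fluorine on the phenyl, with no ring, no donor and no acceptor added.

For compound 4 the step expected is a 1.1-fold higher number from compound 2 to compound 4 (0.05 log units; within the scatter), none beyond the scatter in either direction. Compound 4 is therefore estimated at 0.03 mg/kg, with a range from 0.008 mg/kg to 0.12 mg/kg, close to the value of compound 2 in this assay.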

Compound 4, dose for half-maximal effect: 0.017 mg/kg
The estimate for compound 4 lay 1.8-fold (0.25 log units) above the measured number; the measured number falls inside the stated range.
By their numbers in this assay, from the lowest: compounds 4 and 2 (each within the scatter of the next); then compound 3; then compound 1.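

On the pendant phenyl, the carbon para to a large group takes a fluoro in place of hydrogen without a change in this assay that can be told from the scatter (the step reads a 1.6-fold lower number from compound 2 to compound 4 (0.20 log units; within the scatter)). Compounds 1, 2 and 3 all carry the unsubstituted phenyl and differ only in the fused ring, so they gave no reading on this ring, and the phenyl to 4-fluorophenyl exchange now supplies one: at this carbon, a single fluorine is tolerated on the ring-nitrogen core of compound 2. Nothing measured alongside this pair accounts for the result, and no property of the fluoro can be drawn from it.

One small atom at one carbon leaves open how far this tolerance extends, for instance to a chloro, a methoxy, an amine or a carboxylic acid at the same place, or to a fluoro on the other carbons of the phenyl. On these data alone, it also remains open whether the phenyl to 4-fluorophenyl exchange reads the same on the cores of compound 1 and compound 3.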